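The compounds below may be only part of what the source reports. "The series", "measured", "known", "first", "only" and "open" are said of these compounds alone.

Three compounds share one core and differ only in the aromatic ring attached to it. Compound 1 `CCC1=C(O)c2c(oc(-c3ccc(O)cc3)cc2=O)C(CC)(CC)C1=O` gives 20.6 uM in a functional assay on KBVIN cells (Homo sapiens) for antiproliferative activity, read by sulforhodamine B assay, with a stated time of 3 days; on this read-out higher numbers stand for an effect only at larger amounts of compound and lower numbers for an effect already at smaller amounts. Compound 2 `CCC1=C(O)c2c(oc(-c3ccccc3C)cc2=O)C(CC)(CC)C1=O` gives 2.41 uM, and compound 3 `CCC1=C(O)c2c(oc(-c3ccc(OC)c(C)c3)cc2=O)C(CC)(CC)C1=O` gives 0.1 uM, the lowest of the three. The steps of an 8.5-fold lower number from compound 1 to compound 2 (0.93 log units; beyond the scatter) and a 24-fold lower number from compound 2 to compound 3 (1.38 log units; beyond the scatter) show how strongly this ring shapes the number; the largest is a 210-fold lower number from compound 1 to compound 3 (2.31 log units; beyond the scatter).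

Compound 4 `CCC1=C(O)c2c(oc(-c3ccc(F)c(C)c3)cc2=O)C(CC)(CC)C1=O` is compound 3 with fluoro in place of methoxy on an aromatic carbon. Among the compounds with values here, no measured step swaps exactly these two groups, so the expectation rests on the general weight of this ring seen above. A moderate loss is expected, a 3.5-fold higher number from compound 3 to compound 4 (0.54 log units; beyond the scatter), giving for compound 4 an estimate of 0.35 uM, with a likely range from 0.06 uM to 2 uM.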

Compound 4, concentration for half-maximal effect: 1.62 uM
For compound 4 the middle estimate is 4.6-fold (0.67 log units) below the measured one; the measured number falls inside the stated range.
By their numbers in this assay, from the lowest: compound 3; then compounds 4 and 2 (each within the scatter of the next); then compound 1.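

Replacing methoxy with fluoro at this one position gives a 16-fold higher number from compound 3 to compound 4 (1.21 log units; beyond the scatter), so the methoxy group of compound 3 matters greatly when the neighbouring methyl group stays in place. The 4-fluoro-3-methylphenyl ring still improves on the 4-hydroxyphenyl ring, with a 13-fold lower number from compound 1 to compound 4 (1.10 log units; beyond the scatter). It offers no real gain over the 2-methylphenyl ring, however, with a 1.5-fold lower number from compound 2 to compound 4 (0.17 log units; within the scatter).

As far as these compounds go, whether an ethoxy group, a chlorine atom or an amine at this position would keep the low number of compound 3 stays open. Nothing measured here explains the loss on leaving methoxy.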